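Replacing a 3-hydroxyphenyl with 4-fluorophenyl on a benzimidazole core

The source may hold more compounds than are shown below. What is called first, only, known or untested is meant among the compounds shown, and "the series" means these compounds.

Within the data shown here, compound 1 `COc1cc(-n2cnc3ccc(-c4cccc(O)c4)cc32)cc(OC)c1OC` is the only compound here with a numerical reading in a functional assay on SGC-7901 cells (Homo sapiens) for antiproliferative activity, read by MTT assay, with a stated time of 72 h (a lower number here means a stronger inhibitor, a higher number a weaker inhibitor), where compound 1 gives 53 nM. Compound 2 `COc1cc(-c2ccc3ncn(-c4cc(OC)c(OC)c(OC)c4)c3c2)cc(OC)c1OC` reaches only (the limit of > 10000 nM in this assay, at which 1 of the 2 values shown sits), so for compound 2 the value > 10000 nM is a limit of this assay and not a number. Compound 3 `COc1cc(-n2cnc3ccc(-c4ccc(F)cc4)cc32)cc(OC)c1OC` differs from compound 1 by 4-fluorophenyl in place of 3-hydroxyphenyl on an aromatic carbon. Among the measured compounds shown here, since no measured pair shows this change, its size is unknown; the account expects a loss of potency beyond the usual scatter, with the step from compound 1 to compound 3 estimated at a 5.7-fold higher number from compound 1 to compound 3 (0.75 log units; beyond the scatter). Compound 3 is therefore expected at 300 nM, between 60 nM and 3000 nM.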

Compound 3, half-maximal inhibitory concentration: 3500 nM
Beside the measured number, compound 3's estimate is 12-fold (1.07 log units) below it; measured number outside the range, above it.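

In this assay, putting 4-fluorophenyl in place of 3-hydroxyphenyl gives a 66-fold higher number from compound 1 to compound 3 (1.82 log units; beyond the scatter), so this position on the shared core is sensitive to the aryl group it carries, even though both groups have the same count of heavy atoms. No measurement shown accounts for the size of this loss.

The substituent and its place on the ring change together, so the compounds shown leave open which of the two carries the difference. A 4-hydroxyphenyl or a 3-fluorophenyl would separate them, and a 3-aminophenyl would test another group at that place.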